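Extending a methyl on the core of compound 1 with a silyl ether

The source may report more compounds than this note shows. Statements on the series, on what has been measured and on what is new or still open speak of the compounds shown alone.

Compound 1 `Cn1c(Cc2nn(C)c(=O)c3ccccc23)nnc1SCCCCCCCC(=O)Nc1ccc(Cl)cc1Cl` is the stronger of the two compounds measured here: in an assay on NK92 cells for inhibition of interleukin-15 (Homo sapiens), read by AlphaScreen, with stated times of 30 min and 1 h (on this read-out lower numbers stand for stronger inhibition and higher numbers for weaker inhibition), compound 1 gives 190 nM, while compound 2 `Cn1nc(Cc2nnc(SCCCCCCCC(=O)Nc3ccc(Cl)cc3Cl)n2CCC(=O)O)c2ccccc2c1=O` gives 9500 nM. Among the compounds with values here, the only measured step, a 50-fold higher number from compound 1 to compound 2 (1.70 log units; beyond the scatter), comes from a carboxymethyl in place of hydrogen on a saturated chain carbon bound to an aromatic nitrogen. Compound 3 `Cn1c(Cc2nn(CCCO[Si](C)(C)C(C)(C)C)c(=O)c3ccccc23)nnc1SCCCCCCCC(=O)Nc1ccc(Cl)cc1Cl` changes compound 1 at the same kind of place, but with a different group: a group of 10 heavy atoms (8 carbon, 1 oxygen, 1 silicon; no ring) in place of a hydrogen atom, on a saturated chain carbon bound to an aromatic nitrogen. Within the data shown here, that step bears on it only loosely, since what enters is not a carboxymethyl; still, the one example of growing such a methyl group lost a great deal, so a weaker result than compound 1 is expected, though a smaller loss than that seen for compound 2. For compound 3 the estimate is a step of a 3.2-fold higher number from compound 1 to compound 3 (0.50 log units; beyond the scatter), giving an expected 600 nM in this assay, within a range of 150 nM to 3000 nM.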

Compound 3, half-maximal inhibitory concentration: > 30000 nM
Compound 3: a limit, no number (the forecaster's own chance of this, stated with the estimate: 5%); middle value at least 50-fold (1.69 log units) away from the limit.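

Compound 3 carries a limit of the assay, not a number: the limit of > 30000 nM in this assay, at which 1 of the 3 values shown sits. Even so, the step is readable as an at least 150-fold higher number from compound 1 to compound 3 (2.19 log units; beyond the scatter), so a second enlargement at this kind of place, on a saturated chain carbon bound to an aromatic nitrogen, also brings a large loss in this assay. The earlier step, a 50-fold higher number from compound 1 to compound 2 (1.70 log units; beyond the scatter), involved a carboxymethyl, whereas the group entering compound 3 has no net charge and carries a silicon atom, so a large loss at this kind of place is not tied to one group.

The compounds shown cannot separate the contributions of chain length, the silyl ether and the place of attachment. A small ethyl group, or a chain ending in a free alcohol or an amine, would show whether any growth from this methyl is tolerated.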